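This account rests on a few compounds, and the source may have more. Where it says the series, first, only, none or still open, it means among the compounds named here.

Compound 1 `Cc1ccc(S(=O)(=O)/N=C(/CCNC2=CC(=O)c3ccccc3C2=O)Nc2ccc(F)cc2)cc1` gives 12200 nM in a functional assay on DU-145 cells (Homo sapiens) for cytotoxicity, read by MTT assay, with a stated time of 48 h; on this read-out lower numbers stand for stronger inhibition and higher numbers for weaker inhibition.
Compound 2 `COc1ccc(N/C(CCNC2=CC(=O)c3ccccc3C2=O)=N\S(=O)(=O)c2ccc(C)cc2)cc1OC` gives 17800 nM in this assay.

Among these two measured compounds, compound 2 carries the highest number, with compound 1 as its nearest neighbour; the gap between them, a 1.5-fold higher number from compound 1 to compound 2 (0.16 log units; within the scatter), lies within the scatter, so neither can be called the weaker or the stronger of the pair.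

Compound 3 `Cc1ccc(S(=O)(=O)/N=C(/CCNC2=CC(=O)c3ccccc3C2=O)NC2CCCCC2)cc1` has not yet been measured. It differs from compound 2 in one place, (cyclohexyl in place of 3,4-dimethoxyphenyl on an amine nitrogen). Among the compounds with values here, the only measured step that touches this position, a 1.5-fold higher number from compound 1 to compound 2 (0.16 log units; within the scatter), exchanged one aromatic group for another without moving the number beyond the scatter. Within the data shown here, no measured step replaces an aromatic group with a non-aromatic ring at this amine nitrogen, so the size of such a change is unknown here. On that basis compound 3 is expected to stay close to compound 2, with a step of about a 1.3-fold lower number from compound 2 to compound 3 (0.10 log units; within the scatter) that need not exceed the scatter.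

Compound 3 is estimated at 14000 nM, within a range from 5000 nM to 40000 nM.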

Compound 3, half-maximal inhibitory concentration: 16600 nM
Compound 3: the middle estimate sits 1.2-fold (0.07 log units) below what was measured; measured number inside the range.
By their numbers in this assay, from the lowest: compounds 1, 3 and 2 (each within the scatter of the next).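

Replacing either aromatic group on the amine nitrogen with cyclohexyl, a non-aromatic ring of carbon only, gives small steps in this assay: a 1.1-fold lower number from compound 2 to compound 3 (0.03 log units; within the scatter) and a 1.4-fold higher number from compound 1 to compound 3 (0.13 log units; within the scatter). The earlier pair had shown only one aromatic group exchanged for another, whereas these steps show that a non-aromatic ring at this position also leaves the number within the scatter, even with the 2 hydrogen-bond acceptors of 3,4-dimethoxyphenyl gone. Nothing given here explains this flat picture.

From the compounds shown here alone, all three compounds carry a six-membered ring at this nitrogen, so it remains open whether a small open chain such as methyl, or a group bearing a carboxylic acid or a basic amine, would move the number beyond the scatter. Changes elsewhere on the shared core also remain untested among these compounds.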